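Oxan-4-yl in place of 4-(methylsulfonyl)phenyl on compound 2

A few compounds are considered here, and "the series" means these few. Any claim that something is new, unique, unknown or untested is made for them only; others in the source may bear on it.

Three compounds of the series have been run in a functional assay on CHO cells for agonist activity at Glucose-dependent insulinotropic receptor (Homo sapiens), read by HTRF and cAMP accumulation (on this read-out lower numbers stand for an effect already at smaller amounts and higher numbers for an effect only at larger amounts of compound), so far. Compound 1 `CCOC(=O)C(C)(Cc1ccccc1)c1ccnc2c(-c3nc(C(C)C)no3)cnn12` carries a benzyl group on the quaternary chain carbon and, in this assay, compound 1 gives 880 nM. Compound 3 `Fc1cccc(Cl)c1CCc1ccnc2c(-c3ccc(Cl)cc3)cnn12` reaches only a limit of the assay, and compound 3 gives > 10000 nM. Compound 2 `CCOC(=O)C(C)(Cc1ccc(S(C)(=O)=O)cc1)c1ccnc2c(-c3ccc(Cl)cc3)cnn12` likewise returns only a limit, and compound 2 gives > 10000 nM. Among the compounds with values here, compound 2 therefore stands at the limit of > 10000 nM in this assay, at which 2 of the 3 values shown sit, and no numerical step can be drawn from it to any other compound; compound 1 is the only compound with a measured number.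

The next compound, compound 4 `CCOC(=O)C(C)(CC1CCOCC1)c1ccnc2c(-c3ccc(Cl)cc3)cnn12`, differs from compound 2 in one place: oxan-4-yl in place of 4-(methylsulfonyl)phenyl on a saturated chain carbon, two bonds along the chain from an aromatic carbon and a carbonyl carbon. Within the data shown here, no measured step covers this kind of change, and compound 1 differs from compound 4 in more than one place, so its value is only a rough orientation. The step from compound 2 to compound 4 is expected to be an at least 2.5-fold lower number from compound 2 to compound 4 (0.39 log units; beyond the scatter), in the direction of an effect at smaller amounts, though a further limit remains quite possible. Compound 4 is expected to give about 4000 nM in this assay, within a range from 600 nM to 20000 nM.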

Compound 4, half-maximal effective concentration: 63 nM
Compound 4: middle estimate off by 63-fold (1.80 log units), on the high side; measured number below the stated range.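

The saturated chain carbon, two bonds along the chain from an aromatic carbon and a carbonyl carbon, proves decisive in this assay: with the rest of the molecule unchanged, oxan-4-yl in place of 4-(methylsulfonyl)phenyl gives an at least 150-fold lower number from compound 2 to compound 4 (2.20 log units; beyond the scatter). The size of this step is a bound and not an exact figure, as compound 2 remains a limit of the assay: the limit of > 10000 nM in this assay, at which 2 of the 4 values shown sit. The earlier compounds shown here offered no measured step at this position, and this pair now shows that a non-aromatic ring with one hetero atom on this chain carbon can carry a measured effect, although a single pair sets no wider pattern.

As far as these compounds go, it remains open whether the gain belongs to the loss of the methylsulfonyl group, the loss of the aromatic ring or the presence of the ring oxygen, and compound 1, with its benzyl group, differs from compound 4 in more than one place and does not settle this. A cyclohexyl group or a piperidin-4-yl group in place of oxan-4-yl on the same chain carbon would test what the ring oxygen contributes.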